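This account rests on a few compounds, and the source may have more. Where it says the series, first, only, none or still open, it means among the compounds named here.

Measured compounds in a functional assay on A-431 cells (Homo sapiens) for antiproliferative activity, read by MTT assay, with a stated time of 72 h; a lower number here means a stronger inhibitor, a higher number a weaker inhibitor:

- compound 1 `C#Cc1cccc(Nc2ncnc3cc(OC)c(OCCCCC(=O)Nc4ccc(S(N)(=O)=O)cc4)cc23)c1` gives 17700 nM
- compound 2 `COc1cc2ncnc(Nc3ccc(F)cc3)c2cc1OCCCCC(=O)Nc1ccc(S(N)(=O)=O)cc1` gives 18600 nM
- compound 3 `COc1cc2ncnc(Nc3ccc(Cl)cc3)c2cc1OCCCCC(=O)Nc1ccc(S(N)(=O)=O)cc1` gives 7120 nM

Compound 3 holds the lowest of the three numbers. Its separation from the other two is beyond the scatter in both cases: a 2.5-fold lower number from compound 1 to compound 3 (0.40 log units; beyond the scatter) and a 2.6-fold lower number from compound 2 to compound 3 (0.42 log units; beyond the scatter). Compound 1 and compound 2, by contrast, sit within the scatter of each other, a 1.1-fold higher number from compound 1 to compound 2 (0.02 log units; within the scatter).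

Compound 4 `COc1cc2ncnc(Nc3ccc(Br)cc3)c2cc1OCCCCC(=O)Nc1ccc(S(N)(=O)=O)cc1` is the next member. It differs from compound 3 only in the anilino portion: bromo in place of chloro on an aromatic carbon. Among the compounds with values here, the one measured step that bears on a halogen swap at this position is the fluoro to chloro exchange, a 2.6-fold lower number from compound 2 to compound 3 (0.42 log units; beyond the scatter), which was modest but beyond the scatter. Within the data shown here, no chloro to bromo step has been measured, so the direction of a further halogen change is not established by these data; the single available step points toward a lower number rather than a higher one.

On that basis a small step, a 1.3-fold lower number from compound 3 to compound 4 (0.11 log units; within the scatter), is expected for compound 4, likely within or only just beyond the scatter. The expected value for compound 4 in this assay is 5500 nM, with a range from 2500 nM to 12000 nM.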

Compound 4, half-maximal inhibitory concentration: 6570 nM
Compound 4: the middle estimate sits 1.2-fold (0.08 log units) below what was measured, within the range that was stated.
By their numbers in this assay, from the lowest: compounds 4 and 3 (each within the scatter of the next); then compounds 1 and 2 (each within the scatter of the next).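

In this assay, the chloro to bromo exchange on an aromatic carbon para to a large group gives a 1.1-fold lower number from compound 3 to compound 4 (0.03 log units; within the scatter) and so does not separate these two halogens, whereas the earlier fluoro to chloro exchange did separate its pair. Bromo also stands clear of fluoro, with a 2.8-fold lower number from compound 2 to compound 4 (0.45 log units; beyond the scatter) as the step, and clear of the 3-ethynylphenyl group, with a 2.7-fold lower number from compound 1 to compound 4 (0.43 log units; beyond the scatter) as the step, so the separation first seen with chloro is now seen with a second halogen, while fluoro stays within the scatter of 3-ethynylphenyl. Nothing at hand explains why chloro and bromo group together and fluoro groups apart from them.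

Still open, from the compounds shown here alone, is whether this grouping extends to other groups on the same aromatic carbon, such as iodo, methyl, methoxy or trifluoromethyl. Also open, going by these compounds, is whether the halogen steps keep their size when the chain joining the shared core to the far aryl amide is shorter or longer, or when a carboxylic acid stands in place of the far sulfonamide.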